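Swapping the Hydroxypiperidine for an Open Diamine Chain

The compounds below may be only part of what the source reports. "The series", "measured", "known", "first", "only" and "open" are said of these compounds alone.

Compound 2 `OC1CCN(CCCCOc2ccccc2/C=C/c2ccccc2)CC1` has the lowest number of the three measured compounds in a functional assay on the whole organism with Mus musculus as the target, in the maximal electroshock model, at a dose of 50 mg/kg by the oral route (on this read-out higher numbers stand for more inhibition at the one dose given (going by the name of the read-out) and lower numbers for less inhibition), where compound 2 gives 0%. Compound 1 `C(=C/c1ccccc1OCCCCN1CCCC1)\c1ccccc1` gives 42.9% in this assay, and compound 3 `CN(C)CCCCOc1ccc(/C=C/c2ccccc2)cc1` gives 12.5%. Compound 4 `CN(C)CCN(C)CCCCOc1ccccc1/C=C/c1ccccc1` has not yet been measured; it differs from compound 2 in a single place: (2-(dimethylamino)ethyl)(methyl)amino in place of 4-hydroxypiperidin-1-yl on a saturated chain carbon, four bonds along the chain from an oxygen on an aromatic ring.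

Among the measured compounds shown here, only one measured step touches this same position. Going from the pyrrolidinyl of compound 1 to the 4-hydroxypiperidinyl of compound 2 gave a number 42.9 percentage points lower from compound 1 to compound 2 (beyond the scatter), so the six-membered ring with its hydrogen-bond donor wiped out the effect seen in compound 1. Compound 4 removes that ring and its donor again, but what enters is an open chain carrying a second nitrogen, for which no measured comparison exists. A partial return of the inhibition is therefore expected for compound 4, estimated as a number 20 percentage points higher from compound 2 to compound 4 (beyond the scatter). The estimate for compound 4 is 20%, within a range from 0% to 50%.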

Compound 4, a percentage reported as inhibition, in the whole organism at one dose (the size of the read-out at that dose, not a potency): 0%
For compound 4 the middle estimate is 20 percentage points above the measured one, within the range that was stated.
By their numbers in this assay, from the lowest: compounds 2 and 4 (each within the scatter of the next); then compound 3; then compound 1.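

Replacing 4-hydroxypiperidin-1-yl with the open (2-(dimethylamino)ethyl)(methyl)amino group gives no change at the digits printed from compound 2 to compound 4 (within the scatter) in this assay. Removing that six-membered ring and its hydrogen-bond donor therefore brings back no measurable inhibition when this open chain with its second nitrogen takes their place. The comparison with the pyrrolidin-1-yl group gives a number 42.9 percentage points lower from compound 1 to compound 4 (beyond the scatter), which shows that the inhibition of compound 1 is lost at this chain end with two quite different groups, one a ring with a donor and the other an open chain without one.

Going by these compounds, it remains open whether plain piperidin-1-yl, the ring of compound 2 without its hydroxyl, or a morpholine ring at this place would keep any of the inhibition of compound 1. Nothing given here explains why either replacement differs from pyrrolidin-1-yl.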